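A few compounds are considered here, and "the series" means these few. Any claim that something is new, unique, unknown or untested is made for them only; others in the source may bear on it.

In an ADME assay on BJ cells (Homo sapiens) for cytotoxicity, with a stated time of 72 h (a lower number here means that less compound is needed, a higher number that more compound is needed for the effect), compound 1 `COc1ccc(/C=C/[C@@](C)(/C=C/c2ccc(O)c(C=O)c2)CCC=C(C)C)cc1`, which carries a formyl group on its aromatic ring, gives 9800 nM. Compound 2 `COc1ccc(/C=C/[C@@](C)(/C=C/c2ccc(O)c(/C=C/C(=O)OCc3ccccc3)c2)CCC=C(C)C)cc1` gives only a limit, > 36600 nM. Compound 3 `COc1ccc(/C=C/[C@@](C)(/C=C/c2ccc(O)c(/C=C/C(=O)c3ccccc3)c2)CCC=C(C)C)cc1` also gives only a limit, > 36600 nM, and this is the limit of > 36600 nM in this assay, at which 2 of the 3 values shown sit. Compound 3 therefore has no exact number to start from.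

The next compound, compound 4 `COc1ccc(/C=C/[C@@](C)(/C=C/c2ccc(O)cc2)CCC=C(C)C)cc1`, removes the side group of compound 3: hydrogen in place of 2-benzoylethenyl on an aromatic carbon. In words, hydrogen takes the place of 2-benzoylethenyl on an aromatic carbon, ortho to a hydroxy group.

Within the data shown here, no measured step makes this exact change, but two bear on it. Putting 2-benzoylethenyl in place of formyl gave an at least 3.7-fold higher number from compound 1 to compound 3 (0.57 log units; beyond the scatter), and putting 2-(benzyloxycarbonyl)ethenyl in place of formyl gave an at least 3.7-fold higher number from compound 1 to compound 2 (0.57 log units; beyond the scatter). Both steps lie beyond the scatter, so the group at this place can shift the result. The comparison of the two extended groups, a step that the two limits leave unreadable from compound 2 to compound 3, adds nothing.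

Compound 4 has neither extended group, so it may move back towards compound 1 at 9800 nM, although hydrogen is not formyl. It may equally stay at the limit of the assay. A modest fall in the number is therefore expected, and the expected step is an at least 1.4-fold lower number from compound 3 to compound 4 (0.16 log units; that floor lies within the scatter). Compound 4 is estimated at 25000 nM, with an expected range from 9000 nM to 60000 nM.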

Compound 4, half-maximal effective concentration: > 36600 nM
Compound 4 ended at the assay's limit (the forecaster's own chance of this, stated with the estimate: 45%); at least 1.4-fold (0.16 log units) between middle value and limit.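

In this assay the value of compound 4, > 36600 nM, is a limit and not a number, so its steps to compound 2 and compound 3 cannot be read. The step from the formyl compound can be read: hydrogen in place of formyl gives an at least 3.7-fold higher number from compound 1 to compound 4 (0.57 log units; beyond the scatter), so the higher number does not depend on an extended group at this place, and losing the formyl group is enough to produce it. Of the groups shown on this aromatic carbon, ortho to a hydroxy group, only formyl in compound 1 gives an exact number, while the other three compounds all sit at the same limit: the limit of > 36600 nM in this assay, at which 3 of the 4 values shown sit.

That shared limit leaves open how far compound 2, compound 3 and compound 4 differ from one another, or whether they differ at all. As far as these compounds go, it also remains open whether the lower number of compound 1 requires the formyl group itself or could also be reached with another group on this carbon, such as hydroxymethyl or a carboxylic acid.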